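This account rests on a few compounds, and the source may have more. Where it says the series, first, only, none or still open, it means among the compounds named here.

In an ADME assay on HepG2 cells (Homo sapiens) for cytotoxicity, read by MTT assay, with a stated time of 72 h (on this read-out higher numbers stand for lower toxicity in this test and lower numbers for higher toxicity in this test), compound 1 (`Clc1ccc(/C=N/c2sc3c(c2-c2nc4ccccc4s2)CCC3)cc1`) gives 431 ug/mL and compound 2 (`Fc1ccc(/C=N/c2sc3c(c2-c2nc4ccccc4s2)CCCC3)cc1`) gives 324 ug/mL as its reading. These two closely related compounds are the only ones measured so far. Their numbers lie within the usual scatter of each other, so compound 2 stands level with compound 1 and no ranking can be drawn between them.

Compound 3 (`O=[N+]([O-])c1ccccc1/C=N/c1sc2c(c1-c1nc3ccccc3s1)CCCC2`) has not yet been measured. It differs from compound 2 by a single swap: 2-nitrophenyl in place of 4-fluorophenyl on a carbon with a double bond to nitrogen. Among the compounds with values here, no measured pair shows the effect of this swap, so the expectation rests on thin evidence. Within the data shown here, the only guide is that compound 1 at 431 ug/mL and compound 2 at 324 ug/mL sit close together despite their structural differences. A modest move towards lower numbers is expected, and it may turn out to be no larger than the scatter. The expected change is a 1.3-fold lower number from compound 2 to compound 3 (0.11 log units; within the scatter) on this estimate. For compound 3 the expected value is 250 ug/mL with an estimated range from 90 ug/mL to 600 ug/mL as the plausible span.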

Compound 3, half-maximal cytotoxic concentration: 393 ug/mL
Estimate against measurement, compound 3: 1.6-fold (0.20 log units) below, within the range that was stated.
By their numbers in this assay, from the lowest: compounds 2, 3 and 1 (each within the scatter of the next).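

In this assay, within the data shown here, this is the first direct look at a swap on the carbon with a double bond to nitrogen: 2-nitrophenyl in place of 4-fluorophenyl gives a small step (a 1.2-fold higher number from compound 2 to compound 3 (0.08 log units; within the scatter)). This shows that the group on this carbon can change from 4-fluorophenyl, with no hydrogen-bond acceptors, to the larger 2-nitrophenyl, which brings hydrogen-bond acceptors, without the reading moving beyond the usual scatter of repeated measurements. Nothing measured alongside these readings speaks to what lies behind this result.

The compounds shown leave open whether an amine or a carboxylic acid on the phenyl ring at this place would keep the reading level with compound 2 and compound 3 or carry it clearly away from them. Also open is how the same swap would read on the core of compound 1, where the 2-nitrophenyl group does not appear among the compounds shown, so a single pair of compounds remains the only guide to this change.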